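Ring nitrogen swapped for an exocyclic amine at the nitro-bearing ring

The source may report more compounds than this note shows. Statements on the series, on what has been measured and on what is new or still open speak of the compounds shown alone.

Working notes on the series. The shared core is shown by compound 1 `COc1cc[nH]c1/C=C1\C(=O)Nc2ccc([N+](=O)[O-])cc21`; in a functional assay on MDA-MB-435 cells (Homo sapiens) for antiproliferative activity, read by MTT assay, with a stated time of 5 days (on this read-out higher numbers stand for weaker inhibition and lower numbers for stronger inhibition), compound 1 gives 7460 nM. Compound 2 `COc1cc[nH]c1/C=C1\C(=O)Nc2ccc([N+](=O)[O-])c(N3CC[C@@H](O)C3)c21` carries 3-hydroxypyrrolidin-1-yl in place of hydrogen on an aromatic carbon, and in this assay compound 2 gives 88 nM. Among the compounds with values here, that single change, an 85-fold lower number from compound 1 to compound 2 (1.93 log units; beyond the scatter), is the only step recorded so far, and it leaves compound 2 with the lowest of the two numbers, its nearest neighbour being compound 1.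

Compound 3 `COc1cc[nH]c1/C=C1\C(=O)Nc2ccc([N+](=O)[O-])c(N[C@H]3CC[C@H](O)C3)c21` is not yet measured. It differs from compound 2 by (3-hydroxycyclopentyl)amino in place of 3-hydroxypyrrolidin-1-yl on an aromatic carbon. Within the data shown here, no measured step covers the exchange of one five-membered ring for another at this position; the only step that bears on it is the one from compound 1 to compound 2, which shows that a substituent with a hydroxyl-bearing five-membered ring on this aromatic carbon is linked to a large drop in the number. Since both compound 2 and compound 3 keep such a substituent, the expected step of a 1.7-fold higher number from compound 2 to compound 3 (0.23 log units; within the scatter) is small, likely within the scatter or a modest rise. Compound 3 is therefore estimated at 150 nM, in the range 40 nM to 600 nM.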

Compound 3, half-maximal inhibitory concentration: 1000 nM
Estimate against measurement, compound 3: 6.7-fold (0.82 log units) below; measured number outside the range, above it.
By their numbers in this assay, from the lowest: compound 2; then compound 3; then compound 1.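

In this assay, the two hydroxyl-bearing five-membered rings on this aromatic carbon are not interchangeable: placing (3-hydroxycyclopentyl)amino in the seat of 3-hydroxypyrrolidin-1-yl gives a large step of its own (an 11-fold higher number from compound 2 to compound 3 (1.06 log units; beyond the scatter)). Set against hydrogen, the carbon-only ring group still lowers the number, though this step is modest (a 7.5-fold lower number from compound 1 to compound 3 (0.87 log units; beyond the scatter)), so the identity of the group at this place matters and not merely the presence of a substituent. The exchange alters the ring atoms, the attachment through a ring nitrogen or an exocyclic amine, the hydrogen-bond donors and the defined stereocentres all together, and no supporting data are available to separate these changes or to account for the step.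

From the compounds shown here alone, how a pyrrolidin-1-yl without the hydroxyl, a plain cyclopentylamino group or an open-chain amine such as dimethylamino would stand at this place remains open, so the part played by the hydroxyl and by the ring itself cannot yet be told apart. Also open, going by these compounds, is how the other stereoisomers of the (3-hydroxycyclopentyl)amino group and of the 3-hydroxypyrrolidin-1-yl group would compare.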